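Shifting the Chlorine on the Aryl Group Bound to Nitrogen

The source may report more compounds than this note shows. Statements on the series, on what has been measured and on what is new or still open speak of the compounds shown alone.

Measured so far in a functional assay on A549 cells (Homo sapiens) for antiproliferative activity, read by MTT assay, with a stated time of 24 h; a higher number here means a weaker inhibitor, a lower number a stronger inhibitor:
compound 1, `Cc1ccc(-n2cc(-c3ccccc3NS(=O)(=O)c3c[nH]c(=O)[nH]c3=O)nn2)cc1`, gives 2910 nM
compound 2, `O=c1[nH]cc(S(=O)(=O)Nc2ccccc2-c2cn(-c3ccccc3Cl)nn2)c(=O)[nH]1`, gives 2740 nM

Within the data shown here, compound 2 carries the lower of the two numbers, yet the only measured step, a 1.1-fold lower number from compound 1 to compound 2 (0.03 log units; within the scatter), lies within the scatter, so the two compounds cannot be separated in this assay. Compound 3, `O=c1[nH]cc(S(=O)(=O)Nc2ccccc2-c2cn(-c3cccc(Cl)c3)nn2)c(=O)[nH]1`, has not been measured. It differs from compound 2 in that (3-chlorophenyl in place of 2-chlorophenyl on an aromatic nitrogen). Among the measured compounds shown here, no measured step moves the chlorine from one place on this ring to another; the single step in hand exchanges one whole aryl group for another and produced nothing beyond the scatter. Because a 1.1-fold lower number from compound 1 to compound 2 (0.03 log units; within the scatter) was within the scatter, the step expected for compound 3 is a 1.0-fold higher number from compound 2 to compound 3 (0.01 log units; within the scatter), itself expected to lie within the scatter. Compound 3 is therefore estimated at 2800 nM, with a range from 1400 nM to 5600 nM.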

Compound 3, half-maximal inhibitory concentration: 2340 nM
The estimate for compound 3 lay 1.2-fold (0.08 log units) above the measured number; measured number inside the range.
By their numbers in this assay, from the lowest: compounds 3, 2 and 1 (each within the scatter of the next).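

In this assay, among these compounds, shifting the chlorine from 2-chlorophenyl to 3-chlorophenyl on the aromatic nitrogen gives a 1.2-fold lower number from compound 2 to compound 3 (0.07 log units; within the scatter) and is the first measured move of the chlorine on this ring, with the atoms of the two compounds otherwise unchanged. Exchanging 4-methylphenyl for 3-chlorophenyl at the same place gives a 1.2-fold lower number from compound 1 to compound 3 (0.09 log units; within the scatter) and so, among these three aryl groups, neither the placement of the chlorine nor the exchange of methyl for chlorine separates the compounds in this assay. No measurement is at hand that would explain this result.

On these data alone, it remains open whether an amine or a carboxylic acid on this aryl ring would give a step beyond the scatter. As far as these compounds go, it also remains open whether a butyl chain in place of the whole aryl group would do so.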